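Swapping the anilino ring substituents on a shared purine-free core

The compounds below may be only part of what the source reports. "The series", "measured", "known", "first", "only" and "open" are said of these compounds alone.

Three compounds that share one core differ only in the aromatic ring hanging from a nitrogen on that core. Compound 1 `CC(C)CCn1cnc2c(Nc3ccccc3)nc(N[C@H]3CC[C@H](N)CC3)nc21` carries a plain phenyl, compound 2 `COc1ccc(Nc2nc(N[C@H]3CC[C@H](N)CC3)nc3c2ncn3CCC(C)C)c(OC)c1` a 2,4-dimethoxyphenyl and compound 3 `COc1cc(Nc2nc(N[C@H]3CC[C@H](N)CC3)nc3c2ncn3CCC(C)C)cc(OC)c1` a 3,5-dimethoxyphenyl. In a functional assay on BT-474 cells (Homo sapiens) for inhibition, read by fluorescence, with a stated time of 72 h (a lower number here means a stronger inhibitor of growth, a higher number a weaker inhibitor of growth), compound 1 gives 6400 nM, compound 2 gives 7900 nM and compound 3 gives 5900 nM. Compound 3 has the lowest of the three numbers, but its steps to the others, a 1.1-fold lower number from compound 1 to compound 3 (0.04 log units; within the scatter) and a 1.3-fold lower number from compound 2 to compound 3 (0.13 log units; within the scatter), are both within the scatter, as is a 1.2-fold higher number from compound 1 to compound 2 (0.09 log units; within the scatter); the three compounds cannot be told apart on these numbers.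

Compound 4 `CC(C)CCn1cnc2c(Nc3ccc(O)cc3)nc(N[C@H]3CC[C@H](N)CC3)nc21` alters the same ring once more: 4-hydroxyphenyl in place of 3,5-dimethoxyphenyl on a nitrogen on an aromatic ring. Every measured step on this ring left the numbers where they were, so the same is expected here, with no step beyond the scatter: a 1.0-fold higher number from compound 3 to compound 4 (0.01 log units; within the scatter). A hydroxyl has not appeared in any measured compound, so the range is set a little wider. Compound 4 is therefore estimated at 6000 nM, between 2500 nM and 14000 nM.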

Compound 4, concentration for 50% growth inhibition: 7700 nM
Estimate against measurement, compound 4: 1.3-fold (0.11 log units) below; measured number inside the range.
By their numbers in this assay, from the lowest: compounds 3, 1, 4 and 2 (each within the scatter of the next).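

For the compounds shown here, compound 4 puts a hydroxyl on this ring, where the earlier compounds carried only methoxy groups or nothing, and in this assay the numbers still cannot be told apart: there is a 1.3-fold higher number from compound 3 to compound 4 (0.12 log units; within the scatter) and a 1.0-fold lower number from compound 2 to compound 4 (0.01 log units; within the scatter) and a 1.2-fold higher number from compound 1 to compound 4 (0.08 log units; within the scatter) with hydroxy in place of hydrogen on an aromatic carbon. All three steps are within the scatter, so this position has now taken a plain phenyl, two dimethoxyphenyl rings and a 4-hydroxyphenyl with no readable difference. Nothing available here offers a reason for this flat result.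

Going by these compounds, it remains open whether a different group on this ring, such as an amine, a carboxylic acid or a trifluoromethyl, would shift the number. Also open, on these data alone, is whether a ring other than phenyl, such as a pyridine, would do so.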